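Phenyl in Place of Trifluoromethyl on a Non-Cytotoxic Core

A few compounds are considered here, and "the series" means these few. Any claim that something is new, unique, unknown or untested is made for them only; others in the source may bear on it.

Three compounds built on a shared core were tested in an ADME assay on HCT-116 cells (Homo sapiens) for cytotoxicity, read by CellTiter-Glo, with a stated time of 72 h; a higher number here means a weaker inhibitor, a lower number a stronger inhibitor. Compound 1 `CC1CCN(C2CCN(S(=O)(=O)c3cccc(C(F)(F)F)c3)CC2)CC1` carries a trifluoromethyl group on its aromatic ring. In this assay compound 1 gives > 5000 nM, which is a limit of the assay rather than a number. Compound 2 `CC1CCN(C2CCN(S(=O)(=O)c3ccc(-c4ccccc4)cc3)CC2)CC1` carries a phenyl group on its aromatic ring, and in this assay compound 2 gives > 5000 nM, again only a limit. Compound 3 `COc1ccc(NS(=O)(=O)N2CCC(N3CCC(C)CC3)CC2)cc1`, with a different attachment on the shared core, gives > 5000 nM in this assay, also a limit. Compound 1 therefore stands nowhere in particular: every value shown sits at the limit of > 5000 nM in this assay, at which 3 of the 3 values shown sit, and none of the three compounds can be ranked against another.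

Compound 4 `CC1CCN(C2CCN(S(=O)(=O)c3cccc(-c4ccccc4)c3)CC2)CC1` has not yet been measured. It differs from compound 1 by phenyl in place of trifluoromethyl on an aromatic carbon. Compound 2, which also carries a phenyl, gives > 5000 nM in this assay, and that is a limit. The step is expected to be a step that the limit leaves unreadable from compound 1 to compound 4, that is, none beyond the scatter. Compound 4 is expected to give 12000 nM, within a range from 3000 nM to 60000 nM, most likely reported again as only a limit.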

Compound 4, half-maximal inhibitory concentration: > 5000 nM
Compound 4: a limit, no number (the forecaster's own chance of this, stated with the estimate: 85%); the middle value does not contradict the limit.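

The step from compound 1 to compound 4 cannot be read, as both compounds give only a limit and no number: the limit of > 5000 nM in this assay, at which 4 of the 4 values shown sit.

The compounds shown leave open how phenyl and trifluoromethyl compare on an aromatic carbon of the shared core, and whether any change to that core gives a measurable value in this assay.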